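Cyanoguanidine series: amide to sulfonamide on the ethyl side chain

The compounds below may be only part of what the source reports. "The series", "measured", "known", "first", "only" and "open" are said of these compounds alone.

Three members of the series carry a number in a functional assay on cardiac atrium for antagonist activity at histamine H2 receptor (Cavia porcellus); a higher number here means a more potent compound, by a factor of ten per unit of this negative logarithm, a lower number a less potent compound. Compound 1 `N#CN/C(=N\CCOC(=O)c1ccccc1)NCCCOc1cccc(CN2CCCCC2)c1` gives 7.64, compound 2 `N#CN/C(=N\CCNC(=O)c1ccccc1)NCCCCOc1cccc(CN2CCCCC2)c1` gives 7.67, and compound 3 `N#CN/C(=N\CCNC(=O)CCCc1ccccc1)NCCCOc1cccc(CN2CCCCC2)c1` gives 6.45. Compound 2 holds the highest of the three numbers, yet compound 1 lies within the scatter of it, so no order between those two can be drawn; compound 3 stands lower than compound 2 beyond the scatter. Within the data shown here, only one pair differs in a single place: a number 1.19 log units lower from compound 1 to compound 3 (beyond the scatter), a large drop on exchanging benzoyloxy for ((3-phenylpropyl)carbonyl)amino.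

Compound 4 `N#CN/C(=N\CCNS(=O)(=O)c1ccccc1)NCCCCOc1cccc(CN2CCCCC2)c1` is the next member. Its change against compound 2 is phenylsulfonyl in place of benzoyl on an amine nitrogen. Among the measured compounds shown here, the measured step bears on this only loosely: there the phenyl ring moved away from the carbonyl on a three-carbon chain, whereas here the ring stays directly on the acceptor group and only that group is exchanged. Nothing in the series shows how this assay responds to a sulfonyl in place of a carbonyl, so no step beyond the scatter is firmly expected; the estimate for compound 4 is 7.35, between 6.6 and 8. The step that this estimate implies is a number 0.32 log units lower from compound 2 to compound 4 (beyond the scatter), expected to stay within the scatter.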

Compound 4, negative logarithm of the antagonist equilibrium constant: 7.28
Beside the measured number, compound 4's estimate is 0.07 log units above it, and the stated range covers the measured number.
By their numbers in this assay, from the lowest: compound 3; then compound 4; then compounds 1 and 2 (each within the scatter of the next).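

Among these compounds, the exchange of benzoyl for phenylsulfonyl on an amine nitrogen gives the first reading in this assay of a change to the acceptor group itself, with the phenyl ring still attached directly to it: a number 0.39 log units lower from compound 2 to compound 4 (beyond the scatter). The step is beyond the scatter but modest, so this place accepts a sulfonyl in place of a carbonyl at a measurable but limited cost, and the 2-((phenylsulfonyl)amino)ethyl side chain still leaves compound 4 at 7.28. No measurement on hand accounts for the step, so the data give its size but no reason for it.

Open, going by these compounds, is whether the cost belongs to the sulfonyl as such or to its pairing with a directly attached phenyl ring, which a methylsulfonyl or benzylsulfonyl group on the same amine nitrogen would help to separate. Also open, on these data alone, is whether the step keeps its size on the shorter ether chain of compound 1, and whether a urea or an N-methyl sulfonamide at this place would read closer to compound 2 or to compound 4.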